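Trifluoromethyl for Fluoro on the Carboxy Quinoline Amide

The source may report more compounds than this note shows. Statements on the series, on what has been measured and on what is new or still open speak of the compounds shown alone.

The measured compounds and their values are these:

compound 1, `Cc1c(C(=O)Nc2c(F)cc(-c3cccc(F)c3)cc2F)nc2ccc(F)cc2c1O`: -0.35%
compound 2, `Cc1c(C(=O)Nc2c(F)cc(-c3cccc(F)c3)cc2F)nc2ccc(C(F)(F)F)cc2c1O`: 0.16%
compound 3, `Cc1c(C(=O)Nc2c(F)cc(-c3cccc(F)c3)cc2F)nc2ccc(F)cc2c1C(=O)O`: -0.56%

In a functional assay on A-375 cells (Homo sapiens) for antiproliferative activity, read by MTT assay, with a stated time of 24 h, tested at 0.01 ug/mL (a higher number here means a stronger effect of the compound at the concentration tested, a lower number a weaker effect), compound 3 gives -0.56%, the lowest of the three numbers, yet its gap to compound 1, a number 0.2 percentage points lower from compound 1 to compound 3 (within the scatter), lies within the scatter, as does its gap to compound 2, whose own value is 0.16%. All three compounds sit at the floor of the read-out, so no order among them can be read.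

Compound 4, `Cc1c(C(=O)Nc2c(F)cc(-c3cccc(F)c3)cc2F)nc2ccc(C(F)(F)F)cc2c1C(=O)O`, has not been measured. It differs from compound 3 in one place: trifluoromethyl in place of fluoro on an aromatic carbon

Going by the values given here, one measured step bears directly on this change. Between compound 1 and compound 2 the same trifluoromethyl in place of fluoro on an aromatic carbon gave a number 0.5 percentage points higher from compound 1 to compound 2 (within the scatter), a movement that does not rise above the scatter. Carrying that step onto compound 3, which holds carboxy in place of hydroxy, gives no reason to expect a move beyond the scatter in this assay in either direction. The estimated step from compound 3 to compound 4 is therefore a number 0.6 percentage points higher from compound 3 to compound 4 (within the scatter). Compound 4 is expected to give 0%, within a range from -6% to 6%.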

Compound 4, a percentage reported as inhibition, at one concentration (the size of the read-out at that concentration, not a potency): 0.12%
Estimate against measurement, compound 4: 0.1 percentage points below, and the stated range covers the measured number.
By their numbers in this assay, from the lowest: compounds 3, 1, 4 and 2 (each within the scatter of the next).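

On the carboxy core, the trifluoromethyl change gives a number 0.7 percentage points higher from compound 3 to compound 4 (within the scatter), so in this assay this position has now been tested with the same change on two cores, and neither step stands out: the same change on two cores in this assay, a number 0.5 percentage points higher (within the scatter) from compound 1 to compound 2 and a number 0.7 percentage points higher (within the scatter) from compound 3 to compound 4, 0.2 percentage points apart, within the scatter of two such steps

The carboxy change, previously seen only with fluoro at this position, now also has a trifluoromethyl partner and gives a number 0 percentage points lower from compound 2 to compound 4 (within the scatter), so the two groups do not separate it either: the same change on two cores in this assay, a number 0.2 percentage points lower (within the scatter) from compound 1 to compound 3 and a number 0 percentage points lower (within the scatter) from compound 2 to compound 4, 0.2 percentage points apart, within the scatter of two such steps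

All four compounds remain at the floor of the read-out at this single concentration, so the agreement between these steps is agreement among values close to zero, and it shows neither that the two changes add up nor that they have any effect here.

The compounds shown leave open whether another group at this position, such as an amine, a nitrile or a methoxy group, would lift the read-out off the floor. They also leave open whether fluoro and trifluoromethyl would differ at a higher concentration, or on a core that gives a clear effect in this assay.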